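The compounds below may be only part of what the source reports. "The series", "measured", "known", "first", "only" and "open" are said of these compounds alone.

In a functional assay on MDA-MB-231 cells (Homo sapiens) for antiproliferative activity, with a stated time of 4 days (on this read-out lower numbers stand for stronger inhibition and higher numbers for weaker inhibition), compound 2 (`CCCCc1ccc2[nH]c(-c3ccc(OC)cc3)c(C=O)c2c1`) gives 6.7 nM and stands lowest of the three numbers, with compound 1 (`COc1ccc(-c2[nH]c3ccc(C(C)C)cc3c2C=O)cc1`) at 29 nM and compound 3 (`CCCCc1ccc2[nH]c(-c3ccc(C)cc3)c(C=O)c2c1`) at 34 nM above it. Compound 4 (`CCCCc1ccc2[nH]c(-c3ccc(OC)cc3)c(/C=N\C)c2c1`) differs from compound 2 in one place (a group of 3 heavy atoms (2 carbon, 1 nitrogen; no ring) in place of a group of 2 heavy atoms (1 carbon, 1 oxygen; no ring), on an aromatic carbon), where a group of 3 heavy atoms replaces the formyl on an aromatic carbon. Neither measured step touches that place: a 4.3-fold lower number from compound 1 to compound 2 (0.64 log units; beyond the scatter) came with butyl in place of isopropyl, and a 5.1-fold higher number from compound 2 to compound 3 (0.71 log units; beyond the scatter) came with methyl in place of methoxy. Both are modest and offer only a rough scale, so a modest rise in the number is expected in this assay with wide uncertainty. The estimated change is a 2.2-fold higher number from compound 2 to compound 4 (0.35 log units; beyond the scatter) and no larger than modest. Compound 4 is thus expected at 15 nM (estimated range 4 nM to 70 nM).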

Compound 4, half-maximal inhibitory concentration: 6 nM
Estimate against measurement, compound 4: 2.5-fold (0.40 log units) above, within the range that was stated.
By their numbers in this assay, from the lowest: compounds 4 and 2 (each within the scatter of the next); then compounds 1 and 3 (each within the scatter of the next).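

In this assay, replacing the formyl on this aromatic carbon, two ring bonds from the ring nitrogen, gives a 1.1-fold lower number from compound 2 to compound 4 (0.05 log units; within the scatter) and so leaves the number unchanged within the scatter. Going by these compounds alone, this is the first reading at this position, and it shows that the position accepts the larger group of 3 heavy atoms, at least with butyl and methoxy elsewhere on the core. No available evidence accounts for this result. The compounds shown leave open whether an amine or a carboxylic acid here would hold the number, and whether the same replacement would hold with isopropyl in place of butyl or methyl in place of methoxy.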